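A few compounds are considered here, and "the series" means these few. Any claim that something is new, unique, unknown or untested is made for them only; others in the source may bear on it.

Compound 3 `O=c1cc(Cn2cc(-c3cc(F)cc(F)c3)nn2)c2ccc(O)cc2o1` gives 38900 nM in a functional assay on HepG2 cells (Homo sapiens) for inhibition, read by MTT assay, with a stated time of 72 h (a higher number here means a weaker inhibitor, a lower number a stronger inhibitor), the higher of the two numbers recorded there. Compound 2 `CCCCCCCCc1cn(Cc2cc(=O)oc3cc(O)ccc23)nn1` gives 34200 nM in this assay, and a 1.1-fold higher number from compound 2 to compound 3 (0.06 log units; within the scatter). Compound 1 `O=c1cc(Cn2cc(C3CC3)nn2)c2ccc(O)cc2o1` reaches only the limit > 100000 nM in this assay, which is one of the assay itself (the limit of > 100000 nM in this assay, at which 1 of the 3 values shown sits). From that limit, an at least 2.9-fold lower number from compound 1 to compound 2 (0.46 log units; beyond the scatter) and an at least 2.5-fold lower number from compound 1 to compound 3 (0.41 log units; beyond the scatter).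

Compound 4 `O=c1cc(Cn2cc(-c3ccc(Br)cc3)nn2)c2ccc(O)cc2o1` differs from compound 3 by 4-bromophenyl in place of 3,5-difluorophenyl on an aromatic carbon. For the measured compounds named here, the steps that bear on this change are an at least 2.5-fold lower number from compound 1 to compound 3 (0.41 log units; beyond the scatter), which was beyond the scatter, and a 1.1-fold higher number from compound 2 to compound 3 (0.06 log units; within the scatter), which was within it; no measured step exchanges one substituted phenyl for another. Compound 4 is therefore expected to show no step beyond the scatter, a 1.1-fold lower number from compound 3 to compound 4 (0.05 log units; within the scatter). The estimate for compound 4 is 35000 nM, with a range from 12000 nM to 100000 nM.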

Compound 4, half-maximal inhibitory concentration: 61100 nM
Compound 4: the middle estimate sits 1.7-fold (0.24 log units) below what was measured; the measured number falls inside the stated range.
By their numbers in this assay, from the lowest: compounds 2, 3 and 4 (each within the scatter of the next). At a limit, above all of these: compound 1.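

Exchanging one substituted phenyl for another on this aromatic carbon gives a 1.6-fold higher number from compound 3 to compound 4 (0.20 log units; within the scatter), so this assay does not separate 4-bromophenyl from 3,5-difluorophenyl. The comparison with the long chain likewise gives a 1.8-fold higher number from compound 2 to compound 4 (0.25 log units; within the scatter), leaving the aryl and octyl groups unseparated. The step from the limit of the assay, an at least 1.6-fold lower number from compound 1 to compound 4 (0.21 log units; that floor lies within the scatter), is only a floor: the limit of > 100000 nM in this assay, at which 1 of the 4 values shown sits.

Open, on these data alone, is whether a phenyl bearing an amine or a carboxylic acid, or a chain longer than octyl, would differ beyond the scatter from these compounds. Also open, as far as these compounds go, is how an unsubstituted phenyl would compare at this position.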